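The source may hold more compounds than are shown below. What is called first, only, known or untested is meant among the compounds shown, and "the series" means these compounds.

Compound 1 `OC[C@]1(c2ccc(F)cc2)NC[C@H](O)[C@H]1O` is the weakest of the three measured compounds in an assay on isolated protein for inhibition of lysosomal alpha-glucosidase (Rattus norvegicus), read by colorimetric assay (a lower number here means a stronger inhibitor, a higher number a weaker inhibitor), where compound 1 gives 101000 nM. Compound 2 `CCCC[C@@]1(CO)NC[C@H](O)[C@H]1O` gives 220 nM and compound 3 `C[C@@]1(CO)NC[C@H](O)[C@H]1O` gives 2900 nM, so compound 1 sits far above both, with compound 3 the nearer of the two. For the measured compounds named here, the only measured step that changes one place is a 13-fold higher number from compound 2 to compound 3 (1.12 log units; beyond the scatter); it concerns a substituent on a saturated carbon of the shared core, not the aromatic ring of compound 1, so it does not bear directly on the step to compound 4 `OC[C@]1(c2ccccc2)NC[C@H](O)[C@H]1O`. That step is hydrogen in place of fluoro on an aromatic carbon. Going by the values given here, with no measured pair in which a fluoro on an aromatic carbon is swapped for hydrogen, there is nothing to suggest a shift in either direction. Compound 4 is therefore expected to remain close to compound 1 in this assay, with an estimated step of a 1.1-fold lower number from compound 1 to compound 4 (0.05 log units; within the scatter) that lies within the usual scatter. The estimate for compound 4 is 90000 nM, with a range from 30000 nM to 270000 nM.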

Compound 4, half-maximal inhibitory concentration: 190 nM
Compound 4: middle estimate off by 470-fold (2.68 log units), on the high side, outside the stated range (below it).
By their numbers in this assay, from the lowest: compounds 4 and 2 (each within the scatter of the next); then compound 3; then compound 1.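

In this assay the exchange of fluoro for hydrogen on an aromatic carbon, para to a group of 9 heavy atoms, is a large step (a 530-fold lower number from compound 1 to compound 4 (2.73 log units; beyond the scatter)), so this position is sensitive to the loss of 1 heavy atom. The earlier compounds shown here showed a large step only on a saturated chain carbon (a 13-fold higher number from compound 2 to compound 3 (1.12 log units; beyond the scatter)); this result shows that a change on the aromatic ring can be large too. Nothing available accounts for the size of this step.

Only fluoro and hydrogen are shown at this carbon, so it remains open whether chloro, methyl or methoxy there would give a number close to that of compound 1 or of compound 4. As far as these compounds go, it also remains open whether fluoro on another carbon of the aromatic ring would give a comparable step.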